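Morpholin-4-yl in Place of Piperidin-1-yl on an Amide Carbonyl

The source may report more compounds than this note shows. Statements on the series, on what has been measured and on what is new or still open speak of the compounds shown alone.

Compound 1 `COc1ccc(-n2nc(C(=O)N3CCCCC3)cc2C)nn1` gives > 10000 nM, a limit of the assay.
Compound 2 `COc1ccc(-n2nc(C(=O)N3CCOCC3)cc2C)nn1` gives > 10000 nM, also a limit.
Compound 3 `COc1ccc(-n2nc(CCC(=O)N3CCCCC3)cc2-c2ccc(Cl)cc2)nn1` gives 920 nM.

The measurements come from a functional assay on a cell-free system (Platelet, plasma, Homo sapiens) for inhibition, read by turbidimetry, with a stated time of 3 min; a higher number here means a weaker inhibitor, a lower number a stronger inhibitor. Compound 1 and compound 2 both sit at the limit, so the step that the two limits leave unreadable from compound 1 to compound 2 has no readable size; the change behind it is morpholin-4-yl in place of piperidin-1-yl on a carbonyl carbon. For the measured compounds named here, compound 3 is the only compound with a number, and how its core differs from the core of compound 1 is not broken down here.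

Compound 4 `COc1ccc(-n2nc(CCC(=O)N3CCOCC3)cc2-c2ccc(Cl)cc2)nn1` is not yet measured. It differs from compound 3 by morpholin-4-yl in place of piperidin-1-yl on a carbonyl carbon. This is the same kind of change as that from compound 1 to compound 2, but not the same: in compound 1 the carbonyl carbon has an aromatic carbon as its other neighbour, whereas in compound 3 its other neighbour is a saturated chain carbon. Going by the values given here, the measured pair gives no size for the step, since both values sit at the limit, and the only evidence is the limit of > 10000 nM in this assay, at which 2 of the 3 values shown sit. With nothing to show a large effect, the step from compound 3 to compound 4 is expected to be modest, a 1.6-fold higher number from compound 3 to compound 4 (0.21 log units; within the scatter). For compound 4 the estimate in this assay is 1500 nM, with a range expected from 500 nM to 4500 nM.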

Compound 4, half-maximal inhibitory concentration: 1080 nM
For compound 4 the middle estimate is 1.4-fold (0.14 log units) above the measured one; the measured number falls inside the stated range.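

In this assay, morpholin-4-yl in place of piperidin-1-yl on a carbonyl carbon whose other neighbour is a saturated chain carbon gives a 1.2-fold higher number from compound 3 to compound 4 (0.07 log units; within the scatter), so on the core of compound 3 the two amides cannot be told apart. This shows that, on this one core, the piperidin-1-yl ring can be exchanged for the morpholin-4-yl ring, with its added hydrogen-bond acceptor by count, and the number stays within the scatter. It does not show that the same holds on the core of compound 1, where the carbonyl carbon has an aromatic carbon as its other neighbour, and so the result rests on a single readable pair and the step on the other core cannot be read: the limit of > 10000 nM in this assay, at which 2 of the 4 values shown sit.

The compounds shown leave open whether other groups on the same carbonyl carbon, such as a piperazin-1-yl ring or an open-chain dimethylamino group, or a carboxylic acid in place of the amide, would also stay within the scatter of compound 3. They also leave open how a longer chain between the shared ring and the carbonyl would read, and the cores of compound 1 and compound 3 differ in more than one place, so what separates them remains unresolved.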